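Cyclohexyl to hydrogen: how much the cells tolerate

This account rests on a few compounds, and the source may have more. Where it says the series, first, only, none or still open, it means among the compounds named here.

In an ADME assay on BHK-21 cells (Mesocricetus auratus) for cytotoxicity, read by MTT assay (a lower number here means that less compound is tolerated, a higher number that more compound is tolerated), compound 1 `CC(=O)c1ccc2[nH]c(-c3ccccc3)nc2c1` gives > 100000 nM, which is a limit of the assay and not a number.
In this assay compound 2 `CC(=O)c1ccc2c(c1)nc(-c1ccccc1)n2C1CCCCC1` gives 100000 nM.
In this assay compound 3 `C/C(=N\NC(N)=O)c1ccc2c(c1)nc(-c1ccoc1)n2C1CCCCC1` gives "not determined" (no result reported).

Compound 2 and compound 1 share one core and differ in one place: hydrogen in place of cyclohexyl on an aromatic nitrogen. The step of a number no lower from compound 2 to compound 1 (the limit leaves the size open) has no readable size because compound 1 sits at the limit of > 100000 nM in this assay, at which 1 of the 3 values shown sits.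

Compound 4 `C/C(=N\NC(N)=O)c1ccc2[nH]c(-c3ccoc3)nc2c1` has not been measured. It differs from compound 3 in a single place: hydrogen in place of cyclohexyl on an aromatic nitrogen. How the core of compound 3 differs from the core of compound 2 is not broken down here. The two places are not the same word for word: in compound 2 the ring nitrogen is next to the ring atom that bears a phenyl group, in compound 3 next to the ring atom that bears a furan-3-yl group, so this is the same kind of change, not the same change.

Compound 3 offers no number to step from, so the expectation for compound 4 rests on the other pair. Compound 2 gives 100000 nM in this assay. Compound 1, after the same kind of change, gives > 100000 nM, a limit. Compound 4 is therefore expected near 100000 nM, estimated between 50000 nM and 200000 nM, and a limit rather than a number is quite possible.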

Compound 4, half-maximal cytotoxic concentration: > 100000 nM
Compound 4 was reported as a limit; the forecaster's own chance of this, stated with the estimate: 60%; the middle value lies on the limit itself.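

No step can be read between compound 3 and compound 4: compound 3 offers no number to start from. In this assay compound 4 gives > 100000 nM, which is a limit and not a number: the limit of > 100000 nM in this assay, at which 2 of the 4 values shown sit.

The compounds shown leave open what size the change from cyclohexyl to hydrogen has in either pair, and whether that size is the same with phenyl as with furan-3-yl.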